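Naphthalen-2-yl for 4-Methoxyphenyl on a Weaker Core

This account rests on a few compounds, and the source may have more. Where it says the series, first, only, none or still open, it means among the compounds named here.

Compound 1 `COc1ccc(C2=NN(C3=NC(=O)/C(=C4\C(=O)Nc5ccc(Br)cc54)S3)C(c3ccc(OC)cc3)C2)cc1` and compound 2 `COc1ccc(C2CC(c3ccc4ccccc4c3)=NN2C2=NC(=O)/C(=C3\C(=O)Nc4ccc(Br)cc43)S2)cc1` share one core, while compound 3 `COc1ccc(C2=NN(C3=NC(=O)/C(=C4\C(=O)Nc5ccccc54)S3)C(c3ccc(Cl)cc3)C2)cc1` carries a core whose difference from that of compound 1 is not broken down here. In a functional assay on cells (Cancer cell lines, Homo sapiens) for cytotoxicity, read by sulforhodamine B assay, with a stated time of 48 h (on this read-out higher numbers stand for weaker inhibition of growth and lower numbers for stronger inhibition of growth), compound 1 gives 200 nM, compound 2 gives 50 nM, and compound 3 gives 100000 nM. Within the data shown here, the only measured single change is the step of a 4.0-fold lower number from compound 1 to compound 2 (0.60 log units; beyond the scatter), which is naphthalen-2-yl in place of 4-methoxyphenyl on a carbon with a double bond to nitrogen. Compound 4 `O=C1N=C(N2N=C(c3ccc4ccccc4c3)CC2c2ccc(Cl)cc2)S/C1=C1/C(=O)Nc2ccccc21`, not yet measured, stands to compound 3 as compound 2 stands to compound 1: naphthalen-2-yl in place of 4-methoxyphenyl on a carbon with a double bond to nitrogen. The surroundings are not identical, since the place lies two ring bonds from the ring atom that bears a 4-chlorophenyl group in compound 3, where in compound 1 that ring atom bears a 4-methoxyphenyl group, so this is the same kind of change rather than the same change. Because the step of a 4.0-fold lower number from compound 1 to compound 2 (0.60 log units; beyond the scatter) was modest, the number of compound 3, 100000 nM, is expected to carry most of the weight, and compound 4 is expected to remain weak. In this assay compound 4 is estimated at 30000 nM, between 5000 nM and 100000 nM, a step of a 3.3-fold lower number from compound 3 to compound 4 (0.52 log units; beyond the scatter) that is expected to resemble the earlier one.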

Compound 4, concentration for 50% growth inhibition: 530 nM
Compound 4: the middle estimate sits 57-fold (1.75 log units) above what was measured; measured number outside the range, below it.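

In this assay, naphthalen-2-yl in place of 4-methoxyphenyl gave a 190-fold lower number from compound 3 to compound 4 (2.28 log units; beyond the scatter), so the number fell on this core as it had on the core of compound 1, but the two steps differ in size: the same change on two cores in this assay, a 4.0-fold lower number (0.60 log units; beyond the scatter) from compound 1 to compound 2 and a 190-fold lower number (2.28 log units; beyond the scatter) from compound 3 to compound 4, 47-fold (1.67 log units) apart, beyond the scatter of two such steps. In these two pairs, the direction of the step carried from one core to the other while its size did not, so the step on one core gave no reliable measure of the step on the other. This does not show which difference between the cores sets the size: compound 1 and compound 3 differ in more than one place, and two pairs make no rule for the series.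

The compounds shown leave open how the step would behave if 4-chlorophenyl and 4-methoxyphenyl were exchanged with the rest of the core held fixed. They also leave open whether another group on the carbon with a double bond to nitrogen, such as a dimethylamino group or a carboxylic acid, would follow either step.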